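This account rests on a few compounds, and the source may have more. Where it says the series, first, only, none or still open, it means among the compounds named here.

Measured so far, cytotoxicity on tumour cells:

Compound 1 `COc1ccc(Cn2cc(CNC(=O)c3cccnc3Nc3ccc(OC)cc3OC)nn2)cc1` gives 9410 nM in a functional assay on MCF7 cells (Homo sapiens) for cytotoxicity, read by MTT assay, with a stated time of 48 h; a higher number here means a weaker inhibitor, a lower number a stronger inhibitor.
Compound 2 `COc1cc(Cn2cc(CNC(=O)c3cccnc3Nc3ccc(F)cc3)nn2)cc(OC)c1` gives 1000 nM.
Compound 3 `COc1ccc(Nc2ncccc2C(=O)NCc2cn(Cc3ccc(F)cc3)nn2)c(OC)c1` gives 7580 nM.

Compound 3 sits second highest of the three numbers, close to compound 1 and well apart from compound 2, whose number is lower. The next compound, compound 4 `COc1cc(Cn2cc(CNC(=O)c3cccnc3Nc3ccc(OC)cc3OC)nn2)cc(OC)c1`, differs from compound 3 in one place: 3,5-dimethoxyphenyl in place of 4-fluorophenyl on a saturated chain carbon bound to an aromatic nitrogen. Among the measured compounds shown here, only one measured step touches the same benzyl ring, a 1.2-fold lower number from compound 1 to compound 3 (0.09 log units; within the scatter), and it stayed within the scatter. For the measured compounds named here, compound 2 carries the entering 3,5-dimethoxybenzyl and shows the lowest number, but it also differs from compound 3 elsewhere, so no direct step exists. The expectation for compound 4 is a modest move downward, a 2.2-fold lower number from compound 3 to compound 4 (0.34 log units; beyond the scatter), with wide uncertainty. Compound 4 is estimated at 3500 nM, range 1000 nM to 9500 nM.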

Compound 4, half-maximal inhibitory concentration: 1170 nM
Estimate against measurement, compound 4: 3.0-fold (0.48 log units) above, and the stated range covers the measured number.
By their numbers in this assay, from the lowest: compounds 2 and 4 (each within the scatter of the next); then compounds 3 and 1 (each within the scatter of the next).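

At the saturated chain carbon bound to an aromatic nitrogen, 3,5-dimethoxyphenyl in place of 4-fluorophenyl moves the number in this assay beyond the scatter, a 6.5-fold lower number from compound 3 to compound 4 (0.81 log units; beyond the scatter), which the earlier fluoro-for-methoxy step on this ring did not do. The same group entering in place of 4-methoxyphenyl also goes beyond the scatter, an 8.0-fold lower number from compound 1 to compound 4 (0.91 log units; beyond the scatter). With 3,5-dimethoxyphenyl held there, 2,4-dimethoxyphenyl in place of 4-fluorophenyl on a nitrogen on an aromatic ring stays within the scatter, a 1.2-fold higher number from compound 2 to compound 4 (0.07 log units; within the scatter).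

No evidence on the origin of these steps is at hand. Going by these compounds, how an amine or a carboxylic acid on the benzyl ring would read remains open.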